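The compounds below may be only part of what the source reports. "The series", "measured", "known", "first", "only" and "open" are said of these compounds alone.

Compound 1 `CCOC(=O)C1=Cc2ccccc2OC1(OCc1cn(CC(=O)Nc2ccc(C)cc2)nn1)C(F)(F)F` gives 54300 nM in a functional assay on A549 cells (Homo sapiens) for inhibition, read by MTT assay, with a stated time of 24 h; a lower number here means a stronger inhibitor, a higher number a weaker inhibitor.
Compound 2 `CCOC(=O)C1=Cc2ccccc2OC1(OCc1cn(-c2ccccc2)nn1)C(F)(F)F` gives only a limit, > 150000 nM, in this assay.
Compound 3 `CCOC(=O)C1=Cc2ccccc2OC1(OCc1cn(-c2ccc(F)c([N+](=O)[O-])c2)nn1)C(F)(F)F` gives 11900 nM in this assay.

Compound 3 therefore holds the lowest of the two numbers shown, with compound 1 nearest at a 4.6-fold lower number from compound 1 to compound 3 (0.66 log units; beyond the scatter), while compound 2 sits at the limit of > 150000 nM in this assay, at which 1 of the 3 values shown sits. Compound 4 `CCOC(=O)C1=Cc2ccccc2OC1(OCc1cn(-c2ccc([N+](=O)[O-])cc2)nn1)C(F)(F)F` differs from compound 3 in one place: 4-nitrophenyl in place of 4-fluoro-3-nitrophenyl on an aromatic nitrogen. The step that bears on this is an at least 12-fold lower number from compound 2 to compound 3 (1.10 log units; beyond the scatter), which brought in both the fluorine and the nitro group at once; compound 4 keeps the nitro group but gives up the fluorine. Compound 4 is thus expected to fall between compound 2 and compound 3, a step of a 2.1-fold higher number from compound 3 to compound 4 (0.32 log units; beyond the scatter), so its estimate in this assay is 25000 nM with a range from 8000 nM to 80000 nM.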

Compound 4, half-maximal inhibitory concentration: > 150000 nM
Compound 4: a limit, no number (the forecaster's own chance of this, stated with the estimate: 10%); middle value at least 6.0-fold (0.77 log units) away from the limit.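

In this assay, the change to 4-nitrophenyl gives an at least 12-fold higher number from compound 3 to compound 4 (1.10 log units; beyond the scatter), so a nitro group on this ring does not by itself keep the activity of compound 3. Compound 4 gives only a limit of the assay, shared with compound 2: the limit of > 150000 nM in this assay, at which 2 of the 4 values shown sit. With an at least 2.7-fold higher number from compound 1 to compound 4 (0.44 log units; beyond the scatter), the 4-nitrophenyl group also stands behind ((4-methylphenyl)carbamoyl)methyl at this nitrogen.

The step between the two limits cannot be read. Going by these compounds, whether the fluorine or the place of the nitro group matters stays open, as does how an amine or a carboxylic acid would read there.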